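Nitro on the Fused Ring of Two Related Cores

A few compounds are considered here, and "the series" means these few. Any claim that something is new, unique, unknown or untested is made for them only; others in the source may bear on it.

Compound 1 `CCn1cc(-c2nc3ccccc3[nH]2)c(=O)c2cc(F)c(N3CCNCC3)cc21`: 800 nM
Compound 2 `CCn1cc(-c2nc3ccccc3s2)c(=O)c2cc(F)c(N3CCNCC3)nc21`: 2700 nM
Compound 3 `CCn1cc(-c2nc3ccc([N+](=O)[O-])cc3[nH]2)c(=O)c2cc(F)c(N3CCNCC3)cc21`: 1600 nM

In a functional assay on A2780 cells (Homo sapiens) for cytotoxicity, read by MTT assay, with a stated time of 48 h (a higher number here means a weaker inhibitor, a lower number a stronger inhibitor), compound 1 gives 800 nM and compound 2 gives 2700 nM. How the two cores differ is not broken down here. Compound 3 carries nitro in place of hydrogen on an aromatic carbon, and this change gave a 2.0-fold higher number from compound 1 to compound 3 (0.30 log units; within the scatter).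

Compound 4 `CCn1cc(-c2nc3ccc([N+](=O)[O-])cc3s2)c(=O)c2cc(F)c(N3CCNCC3)nc21` is not yet measured. It arises from compound 2 by nitro in place of hydrogen on an aromatic carbon, the same change that turned compound 1 into compound 3. The step from compound 2 to compound 4 in this assay is expected to be a 1.9-fold higher number from compound 2 to compound 4 (0.27 log units; within the scatter), resting on the earlier step of a 2.0-fold higher number from compound 1 to compound 3 (0.30 log units; within the scatter) seen on the other core, so a similar small shift is expected here. The estimate for compound 4 in this assay is 5000 nM, with a plausible range from 2000 nM to 14000 nM.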

Compound 4, half-maximal inhibitory concentration: 200000 nM
Beside the measured number, compound 4's estimate is 40-fold (1.60 log units) below it; measured number above the stated range.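

In this assay, nitro in place of hydrogen on an aromatic carbon gave a 74-fold higher number from compound 2 to compound 4 (1.87 log units; beyond the scatter). The same change therefore did not carry over in size from one core to the other, as the two steps set side by side show: the same change on two cores in this assay, a 2.0-fold higher number (0.30 log units; within the scatter) from compound 1 to compound 3 and a 74-fold higher number (1.87 log units; beyond the scatter) from compound 2 to compound 4, 37-fold (1.57 log units) apart, beyond the scatter of two such steps

This single pair of steps shows that the size of the change depends on the core here, but not which difference between the two cores is responsible, nor whether other groups would behave the same way.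

The compounds shown leave open whether an amine or a carboxylic acid on the same aromatic carbon would show a similar gap between the cores. They also leave open how nitro would act on a core differing from that of compound 1 in only one place.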